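The source may report more compounds than this note shows. Statements on the series, on what has been measured and on what is new or still open speak of the compounds shown alone.

Compound 2, `CC(C)=CC(=O)Nc1cccc(Oc2nc(Nc3cccc(C#N)c3)nc3ccsc23)c1`, gives 41100 nM in a functional assay on MCF7 cells (Homo sapiens) for inhibition, read by MTT assay, with a stated time of 72 h; a lower number here means a stronger inhibitor, a higher number a weaker inhibitor; compound 1, `COc1cccc(Nc2nc(Oc3cccc(NC(=O)/C=C/C(C)C)c3)c3sccc3n2)c1`, gives 43900 nM in this assay. Compound 2 holds the lower of the two numbers, but its gap to compound 1 lies within the scatter, so the two cannot be ranked. Compound 3, `CC(C)/C=C/C(=O)Nc1cccc(Oc2nc(Nc3cccc(C#N)c3)nc3ccsc23)c1`, differs from compound 2 by 3-methylbut-1-en-1-yl in place of 2-methylprop-1-en-1-yl on a carbonyl carbon. Within the data shown here, no measured pair shows this change, so no step beyond the scatter is expected in either direction. Compound 3 is estimated at 42000 nM, between 20000 nM and 90000 nM. The expected step is a 1.0-fold higher number from compound 2 to compound 3 (0.01 log units; within the scatter).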

Compound 3, half-maximal inhibitory concentration: > 50000 nM
Compound 3: only a limit was reported; the forecaster's own chance of this, stated with the estimate: 10%; at least 1.1-fold (0.07 log units) between middle value and limit.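

Compound 3 reads only as a limit in this assay, not as a number: the limit of > 50000 nM in this assay, at which 1 of the 3 values shown sits. On these data alone, the change to 3-methylbut-1-en-1-yl on this carbonyl carbon reads as an at least 1.2-fold higher number from compound 2 to compound 3 (0.08 log units; that floor lies within the scatter), so it brings no gain here, and the true size of the step stays unknown. Cyano in place of methoxy on an aromatic carbon reads as an at least 1.1-fold higher number from compound 1 to compound 3 (0.05 log units; that floor lies within the scatter), again only a floor.

As far as these compounds go, whether an amine, a carboxylic acid or a longer chain on this carbonyl carbon would lower the number stays open.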